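Replacing Bromo with Hydrogen on Compound 1

The compounds below may be only part of what the source reports. "The series", "measured", "known", "first", "only" and "open" are said of these compounds alone.

Among the measured compounds shown here, in a functional assay, read by spectrophotometry, with a stated time of 6 min (on this read-out higher numbers stand for weaker inhibition and lower numbers for stronger inhibition), compound 1 `CCCCCCCCCCOc1cc(OC)c(Br)cc1C(C)=O` gives 34700000 nM and compound 2 `CCCCCCCCCCCCOc1cc(OC)c(Br)cc1C(C)=O` gives 32700000 nM so compound 1 stands level with the only other measured compound. That step a 1.1-fold lower number from compound 1 to compound 2 (0.03 log units; within the scatter) lies on the saturated chain, so it bears only loosely on compound 3 `CCCCCCCCCCOc1cc(OC)ccc1C(C)=O` which carries hydrogen in place of bromo on an aromatic carbon in its core. For the measured compounds named here, no measured step covers this change, so no shift beyond the scatter is expected. The expected step is a 1.2-fold higher number from compound 1 to compound 3 (0.06 log units; within the scatter) with wide uncertainty. For compound 3 the estimated value is 40000000 nM (expected range 15000000 nM to 100000000 nM).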

Compound 3, half-maximal inhibitory concentration: 41700000 nM
The estimate for compound 3 lay 1.0-fold (0.02 log units) below the measured number, and the stated range covers the measured number.
By their numbers in this assay, from the lowest: compounds 2, 1 and 3 (each within the scatter of the next).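

At this aromatic carbon, ortho to a methoxy group and meta to an acetyl group, hydrogen in place of bromo gives a 1.2-fold higher number from compound 1 to compound 3 (0.08 log units; within the scatter) in this assay, so inhibition on this read-out does not depend on the bromo group. This is the first change shown on the shared core rather than on the saturated chain, and like the chain step, it stays within the scatter. No supporting evidence bears on this result. On these data alone, whether an amine or a carboxylic acid at this carbon would shift the number remains open. So does the effect of changing the acetyl group.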